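Working notes: aryl exchange from compound 3 to compound 4

This account rests on a few compounds, and the source may have more. Where it says the series, first, only, none or still open, it means among the compounds named here.

Measured in a functional assay on ileum (Cavia porcellus) for antagonist activity (a lower number here means a stronger inhibitor, a higher number a weaker inhibitor), so far:
- compound 1 `O=C(O)c1ccc(OCCCOc2ccc3c(O)c([N+](=O)[O-])c(=O)oc3c2)cc1` gives > 20000 nM as a limit of the assay
- compound 2 `Cc1ccccc1OCCCOc1ccc2c(O)c([N+](=O)[O-])c(=O)oc2c1` gives 590 nM
- compound 3 `CCc1ccccc1OCC(O)COc1ccc2c(O)c([N+](=O)[O-])c(=O)oc2c1` gives 2700 nM

The number for compound 3 stands higher than the number for compound 2 in these readings, a gap beyond the scatter: compound 2 gives 590 nM, and compound 3 gives 2700 nM. Compound 4 `CCCc1cc(F)ccc1OCC(O)COc1ccc2c(O)c([N+](=O)[O-])c(=O)oc2c1` has 4-fluoro-2-propylphenyl in place of 2-ethylphenyl on an oxygen on a saturated carbon. Among the measured compounds shown here, the only measured step at this place, an at least 33-fold lower number from compound 1 to compound 2 (1.53 log units; beyond the scatter), is large, but it removes 4-carboxyphenyl, which the present change does not. For the measured compounds named here, no measured step covers propyl or fluorine. No step beyond the scatter is therefore expected in this assay, with a slight lean towards a lower number. The expected step is a 1.4-fold lower number from compound 3 to compound 4 (0.13 log units; within the scatter) in this estimate. For compound 4 the estimate is 2000 nM, with an expected range from 600 nM to 6500 nM for a repeat measurement.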

Compound 4, half-maximal inhibitory concentration: 140 nM
Compound 4: middle estimate off by 14-fold (1.15 log units), on the high side; measured number outside the range, below it.
By their numbers in this assay, from the lowest: compound 4; then compound 2; then compound 3. At a limit, above all of these: compound 1.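

In this assay, 4-fluoro-2-propylphenyl in place of 2-ethylphenyl gives a 19-fold lower number from compound 3 to compound 4 (1.29 log units; beyond the scatter). A large step at this place therefore does not require the removal of 4-carboxyphenyl: exchange between two uncharged aryl groups, neither with hydrogen-bond donors or acceptors, is enough. No measured property bears on why the number falls.

The step joins two changes, propyl for ethyl and the added fluorine, and the compounds shown do not separate their shares. Going by these compounds, whether a butyl chain in place of propyl, or chlorine in place of fluorine, extends the step remains open.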